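This account rests on a few compounds, and the source may have more. Where it says the series, first, only, none or still open, it means among the compounds named here.

Within the data shown here, in a functional assay on the whole organism (strain Hartley) for inhibition, with Cavia porcellus as the target, with stated times of 15 min and 2 min (on this read-out higher numbers stand for an effect only at larger amounts of compound and lower numbers for an effect already at smaller amounts), compound 3 `CCCCC1([C@H](O)/C=C/C2[C@H](O)CC(=O)[C@@H]2C/C=C\CCCC(=O)O)CCC1` gives 0.00154 mg/kg, the lowest number so far. Compound 1 `CCCCC1([C@@H](O)/C=C/C2CCC(=O)[C@@H]2CCCCCCC(=O)O)CCC1` gives 0.0139 mg/kg and compound 2 `CCCCC1([C@@H](O)/C=C/C2CCC(=O)[C@@H]2CCCCCCC(=O)OCC)CCC1` gives 0.032 mg/kg. The next structure, compound 4 `CCCCC1([C@H](O)/C=C/C2CCC(=O)[C@@H]2C/C=C\CCCC(=O)O)CCC1`, has hydrogen in place of hydroxy on a saturated ring carbon. Among the measured compounds shown here, no measured step covers this exchange. For the measured compounds named here, the one available step, a 2.3-fold higher number from compound 1 to compound 2 (0.36 log units; beyond the scatter), puts ethyl in place of hydrogen elsewhere in the molecule, so it gives little guidance here beyond showing that a single change can move the number in this assay. The closer guide is compound 1 at 0.0139 mg/kg, which also has no hydroxy on that ring carbon, although its chain differs. A clear move towards a higher number is therefore expected, landing near that value, and the expected step is a 5.8-fold higher number from compound 3 to compound 4 (0.77 log units; beyond the scatter). The estimated value for compound 4 is 0.009 mg/kg, with an expected range of 0.0025 mg/kg to 0.03 mg/kg.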

Compound 4, dose for half-maximal effect: 0.0022 mg/kg
Estimate against measurement, compound 4: 4.1-fold (0.61 log units) above; measured number below the stated range.
By their numbers in this assay, from the lowest: compounds 3 and 4 (each within the scatter of the next); then compound 1; then compound 2.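

In this assay the exchange of hydroxy for hydrogen on the saturated ring carbon gives a 1.4-fold higher number from compound 3 to compound 4 (0.15 log units; within the scatter) and so leaves compound 3 and compound 4 indistinguishable. Among these compounds, this is the first reading at this position: with the 6-carboxyhex-2-en-1-yl group and the rest of the core held the same, the hydroxy on this ring carbon is not required for a number in this range. No evidence at hand bears on this result.

The compounds shown carry only hydroxy or hydrogen on this ring carbon, so it remains open how a methyl group, a fluorine or an amine there would read. On these data alone, it also remains open whether the exchange would read the same on the ethyl ester of the side-chain carboxylic acid.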